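The source may report more compounds than this note shows. Statements on the series, on what has been measured and on what is new or still open speak of the compounds shown alone.

Working notes on the series. Three compounds sharing one core have been run in a functional assay on MCF7 cells (Homo sapiens) for inhibition, read by CCK-8 assay, with a stated time of 48 h (on this read-out higher numbers stand for weaker inhibition of growth and lower numbers for stronger inhibition of growth), so far. Compound 1 `Cc1ccccc1Nc1nc(NCc2ccccc2)ncc1Cl` sits at the assay limit: in this assay compound 1 gives > 100000 nM, which is a limit rather than a number (the limit of > 100000 nM in this assay, at which 1 of the 3 values shown sits). Of the two compounds that return a number, compound 2 `Cc1ccccc1Nc1nc(Nc2ccc(N3CCN(C(=O)OC(C)(C)C)CC3)cc2)ncc1Cl` gives 2250 nM in this assay, and compound 3 `CN1CCN(c2ccc(Nc3ncc(Cl)c(NCc4ccc(F)cc4)n3)nc2)CC1` gives 19300 nM in this assay. Compound 3 therefore stands with the highest number of the two, and the gap down to compound 2 lies beyond the usual scatter.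

The next compound, compound 4 `Cc1cc(C)c(Nc2nc(Nc3ccc(N4CCN(C)CC4)cn3)ncc2Cl)c(C)c1`, differs from compound 3 at a single site (2,4,6-trimethylphenyl in place of 4-fluorobenzyl on a nitrogen on an aromatic ring). Going by the values given here, no single-change step between measured compounds covers this exchange, so the size can only be expected, not read off. What the numbers show is that compound 2, which carries an arylamino group at this nitrogen, returns a much lower number than compound 3, which carries a benzylamino group there; compound 1, the other benzyl-bearing compound, returns only a limit. On that basis the step from compound 3 to compound 4 in this assay is expected to be a clear fall in number, roughly a 5.5-fold lower number from compound 3 to compound 4 (0.74 log units; beyond the scatter), beyond the scatter. For compound 4 in this assay the estimate is 3500 nM, with a range from 900 nM to 14000 nM.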

Compound 4, concentration for 50% growth inhibition: 9470 nM
Estimate against measurement, compound 4: 2.7-fold (0.43 log units) below; measured number inside the range.
By their numbers in this assay, from the lowest: compound 2; then compound 4; then compound 3. At a limit, above all of these: compound 1.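

Going by these compounds alone, this is the first single-change step at this position: on a nitrogen on an aromatic ring, 2,4,6-trimethylphenyl in place of 4-fluorobenzyl gives, in this assay, a 2.0-fold lower number from compound 3 to compound 4 (0.31 log units; beyond the scatter), modest in size though beyond the scatter. The earlier compounds shown here differ from one another in more than one place, so they could not separate this exchange from their other differences; this step isolates it and ties only a modest change to it. No measurement at hand gives a cause for this step.

The step combines two changes in the group, the loss of the carbon link between the nitrogen and the ring and the exchange of the ring's substituents, and 4-fluorophenyl or plain phenyl on this nitrogen, with the rest of compound 3 kept, would be needed to tell these apart. Within the data shown here, also open is how the exchange behaves on the other compounds, since compound 1 and compound 2 each differ from compound 3 and compound 4 in more than one place and no step to them can be read.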